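This account rests on a few compounds, and the source may have more. Where it says the series, first, only, none or still open, it means among the compounds named here.

Working notes on the amide series around the shared core. Compound 1 `CNC(=O)c1ccc(-c2ccc(Cl)cc2)c(N)n1` gives only a limit in an assay on HEK293 cells for inhibition of sodium channel protein type 10 subunit alpha (Homo sapiens), read by fluorescence (a lower number here means a stronger inhibitor, a higher number a weaker inhibitor), > 32000 nM. Compound 2 `Cn1nccc1C(=O)Nc1ccc(-c2ccccc2OC(F)(F)F)c(N)n1` gives 2400 nM in this assay. Compound 3 `Cn1nncc1C(=O)Nc1ccc(-c2ccccc2OC(F)(F)F)c(N)n1` gives 7000 nM, the highest of the two numbers this assay returns; the nearest is compound 2, separated by a 2.9-fold higher number from compound 2 to compound 3 (0.46 log units; beyond the scatter). Compound 4 `Nc1nc(NC(=O)c2ccccc2)ccc1-c1ccccc1OC(F)(F)F` differs from compound 3 by phenyl in place of 1-methyl-1H-1,2,3-triazol-5-yl on a carbonyl carbon. Among the compounds with values here, only one measured step touches that carbonyl carbon, a 2.9-fold higher number from compound 2 to compound 3 (0.46 log units; beyond the scatter), an exchange of one five-membered ring for another; no measured step covers a six-membered ring of carbon only at that place, so the bounds stay wide. Compound 4 is expected to give about 3500 nM, between 1000 nM and 12000 nM. That estimate means a 2.0-fold lower number from compound 3 to compound 4 (0.30 log units; within the scatter), a modest expected step toward a lower number.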

Compound 4, half-maximal inhibitory concentration: 3200 nM
For compound 4 the middle estimate is 1.1-fold (0.04 log units) above the measured one; measured number inside the range.
By their numbers in this assay, from the lowest: compounds 2 and 4 (each within the scatter of the next); then compound 3. At a limit, above all of these: compound 1.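

On the carbonyl carbon, phenyl in place of 1-methyl-1H-1,2,3-triazol-5-yl gives a 2.2-fold lower number from compound 3 to compound 4 (0.34 log units; beyond the scatter) in this assay and shows that a ring of carbon only can stand at this place without hetero atoms. Phenyl in place of 1-methyl-1H-pyrazol-5-yl gives a 1.3-fold higher number from compound 2 to compound 4 (0.12 log units; within the scatter) and leaves these two groups indistinguishable. Nothing at hand gives a cause for either step.

Open, on these data alone, is whether an amine or a carboxylic acid on the phenyl, or a saturated ring such as piperidine at the carbonyl carbon, would change the number.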